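Moving the hydroxyl on a shared three-ring pyridine core

This account rests on a few compounds, and the source may have more. Where it says the series, first, only, none or still open, it means among the compounds named here.

Compound 1 `Oc1ccccc1-c1cc(-c2ccccn2)cc(-c2ccccc2O)n1` is tested in a functional assay on DU-145 cells (Homo sapiens) for cytotoxicity, read by CCK-8 assay; a higher number here means a weaker inhibitor, a lower number a stronger inhibitor. In this assay compound 1 reaches only the limit of > 50000 nM. Compound 2 `Oc1cccc(-c2cc(-c3ccccn3)cc(-c3ccccc3O)n2)c1` gives 17100 nM in this assay. The change 3-hydroxyphenyl in place of 2-hydroxyphenyl on an aromatic carbon produces an at least 2.9-fold lower number from compound 1 to compound 2 (0.46 log units; beyond the scatter). Compound 3 `Oc1ccccc1-c1cc(-c2cccnc2)cc(-c2ccccc2O)n1` also stops at the limit of > 50000 nM. The core of compound 3 differs from that of compound 1 by pyridin-3-yl in place of pyridin-2-yl on an aromatic carbon, a change giving a step that the two limits leave unreadable from compound 1 to compound 3; this follows from the limit of > 50000 nM in this assay, at which 2 of the 3 values shown sit. Compound 4 `Oc1cccc(-c2cc(-c3cccnc3)cc(-c3ccccc3O)n2)c1` is not yet measured. It differs from compound 3 by 3-hydroxyphenyl in place of 2-hydroxyphenyl on an aromatic carbon, the same kind of change as that from compound 1 to compound 2, though here the place is meta to a pyridin-3-yl group rather than meta to a pyridin-2-yl group. Beside the earlier step, the expected step in this assay is an at least 2.0-fold lower number from compound 3 to compound 4 (0.30 log units; that floor lies within the scatter), resting on the measured step of an at least 2.9-fold lower number from compound 1 to compound 2 (0.46 log units; beyond the scatter). Compound 4 is estimated at 25000 nM, between 9000 nM and 60000 nM.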

Compound 4, half-maximal inhibitory concentration: 5580 nM
The estimate for compound 4 lay 4.5-fold (0.65 log units) above the measured number, outside the stated range (below it).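

In this assay the change to 3-hydroxyphenyl in place of 2-hydroxyphenyl carried over to the second core, giving an at least 8.9-fold lower number from compound 3 to compound 4 (0.95 log units; beyond the scatter) in the same direction as on the first. Pyridin-3-yl in place of pyridin-2-yl gave a 3.1-fold lower number from compound 2 to compound 4 (0.49 log units; beyond the scatter) where a 3-hydroxyphenyl group is present, while the same change between the two compounds held at the assay limit cannot be read. Only two cores are compared, and each step starts from a limit rather than a number, so no difference in the size of the change is shown: the same change on two cores in this assay, an at least 2.9-fold lower number (0.46 log units; beyond the scatter) from compound 1 to compound 2 and an at least 8.9-fold lower number (0.95 log units; beyond the scatter) from compound 3 to compound 4; the limit leaves it open whether they differ.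

The compounds shown leave open whether the step would hold if an amine or a methoxy group took the place of the hydroxyl. They also leave open whether the same change at the remaining 2-hydroxyphenyl group of compound 4 would lower the number further.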